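The compounds below may be only part of what the source reports. "The series", "measured", "known", "first", "only" and "open" are said of these compounds alone.

Compound 1 `COc1cc(/C=N/NC(=O)CCN2CCN(c3ccnc4cc(Cl)ccc34)CC2)ccc1OC(C)C` gives 8800 nM in an ADME assay on cells (Splenocyte, Mus musculus, strain BALB/c) for cytotoxicity, read by thymidine incorporation, with a stated time of 24 h; a lower number here means a stronger inhibitor, a higher number a weaker inhibitor. Compound 2 `COc1cc(/C=N/NC(=O)CCN2CCN(c3ccnc4cc(Cl)ccc34)CC2)c(Br)c(OC)c1OC` gives 9600 nM in this assay. Compound 1 stands at the lower end of these two numbers, yet the gap to compound 2 lies within the scatter, so no order between them can be claimed. Compound 3 `CC(C)Oc1ccc(/C=N/NC(=O)CCN2CCN(c3ccnc4cc(Cl)ccc34)CC2)cc1` differs from compound 1 by hydrogen in place of methoxy on an aromatic carbon. Among the measured compounds shown here, no measured step of this kind is available. The author expects a step no larger than the scatter, a 1.0-fold higher number from compound 1 to compound 3 (0.01 log units; within the scatter), in either direction. Compound 3 is therefore expected to give about 9000 nM, between 4000 nM and 20000 nM.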

Compound 3, half-maximal inhibitory concentration: 3600 nM
Estimate against measurement, compound 3: 2.5-fold (0.40 log units) above; measured number outside the range, below it.
By their numbers in this assay, from the lowest: compound 3; then compounds 1 and 2 (each within the scatter of the next).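

Replacing methoxy with hydrogen on this aromatic carbon, ortho to an isopropoxy group, brings a 2.4-fold lower number from compound 1 to compound 3 (0.39 log units; beyond the scatter) in this assay and shows that the number responds to a change at this position. Compounds 1 and 2 differ in more than one place and could not show this. The data offer no measured basis for explaining the step.
As far as these compounds go, whether a hydroxyl group, a fluorine atom or a longer ether chain at this position would move the number in the same direction remains open. So does whether the step persists with an amine in place of the isopropoxy group.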